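Chloro for fluoro on the anilide: expected cytotoxicity

This account rests on a few compounds, and the source may have more. Where it says the series, first, only, none or still open, it means among the compounds named here.

Compound 1 `Cc1nc(C(NC(=O)C(=O)Nc2ccc(F)c(F)c2)C2CCCCN2)sc1CO` in an ADME assay on TZM-b1 cells (Homo sapiens) for cytotoxicity, read by XTT assay, with a stated time of 3 days (a lower number here means that less compound is tolerated, a higher number that more compound is tolerated), gives > 87000 nM, which is a limit of the assay rather than a number.
Compound 2 `Cc1nc(C(NC(=O)C(=O)Nc2ccc(F)cc2)C2CCCCN2)sc1CCO` in this assay gives > 88000 nM, again a limit.
Compound 3 `Cc1nc(C(NC(=O)C(=O)Nc2ccc(Cl)cc2)C2CCCNC2)sc1CCO` in this assay gives 59400 nM.

Among the measured compounds shown here, compound 1 stands at the limit described by the limit of > 87000 nM in this assay, at which 1 of the 3 values shown sits, so only a lower bound is known for it; compound 2 sits at a limit as well, while compound 3 is the one compound here with a measured number. For the measured compounds named here, no step between two measured compounds differing in one place is available. Compound 4 `Cc1nc(C(NC(=O)C(=O)Nc2ccc(F)c(Cl)c2)C2CCCCN2)sc1CO` differs from compound 1 by chloro in place of fluoro on an aromatic carbon. The step of an at least 1.0-fold lower number from compound 1 to compound 4 (0.03 log units; that floor lies within the scatter) is expected to stay within the scatter. Compound 4 is thus estimated at 80000 nM, in the range 40000 nM to 150000 nM, with a fair chance that this assay again reports only a limit.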

Compound 4, half-maximal cytotoxic concentration: > 77800 nM
Compound 4: only a limit was reported; the forecaster's own chance of this, stated with the estimate: 55%; the middle value is on the limit's open side.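

Among the compounds shown here, compound 1 and compound 4 each give only a limit in this assay, so no step between them can be read. The compounds shown leave open whether chloro in place of fluoro changes cytotoxicity at all.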